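A few compounds are considered here, and "the series" means these few. Any claim that something is new, unique, unknown or untested is made for them only; others in the source may bear on it.

Working notes on the series. Of the compounds shown here, two are measured so far in a functional assay on cells (Homo sapiens) for cytotoxicity; a higher number here means that more compound is tolerated, a lower number that less compound is tolerated. Compound 1 `O=C1N(CCCCCCOc2ccc(Cl)cc2)CCN1c1ccncc1` gives > 25000 nM, which is a limit of the assay. Compound 2 `O=C1N(CCCCCCOc2ccc(Cl)cc2)CCN1c1ccncn1` gives > 25000 nM, also a limit of the assay. The step that the two limits leave unreadable from compound 1 to compound 2 can therefore not be read, as the limit of > 25000 nM in this assay, at which 2 of the 2 values shown sit, shows. Compound 3 `O=C1N(CCCCCCCOc2ccc(Br)cc2)CCN1c1ccncn1` is not yet measured; it differs from compound 2 by (4-bromophenoxy)methyl in place of 4-chlorophenoxy on a saturated chain carbon, six bonds along the chain from an amide-type nitrogen in a ring. Among the measured compounds shown here, no measured step touches this part of the molecule: the only step in hand concerns the heteroaryl on the other ring nitrogen, and its size is not readable. On the numbers in hand, with both compounds at the limit, no change beyond the scatter is expected, and the step from compound 2 to compound 3 is estimated as a number no higher from compound 2 to compound 3 (the limit leaves the size open). Compound 3 is accordingly expected at 25000 nM, within 10000 nM to 60000 nM, most likely again reported only as a limit.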

Compound 3, half-maximal cytotoxic concentration: > 25000 nM
Compound 3 ended at the assay's limit (the forecaster's own chance of this, stated with the estimate: 85%); the middle value lies on the limit itself.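

The step from compound 2 to compound 3 cannot be read in this assay, as compound 3 joins compound 1 and compound 2 at the same limit: the limit of > 25000 nM in this assay, at which 3 of the 3 values shown sit. The compounds shown leave open where the half-maximal cytotoxic concentration of any of them actually lies, and whether either structural change alters it.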